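Pyrazole anti-inflammatory series: methoxy for methyl step

This account rests on a few compounds, and the source may have more. Where it says the series, first, only, none or still open, it means among the compounds named here.

Measured compounds:
compound 1 `Cc1ccc(-c2nn(-c3ccc(Cl)cc3)cc2/C=N\c2ccccc2)cc1`: 49.3%
compound 2 `COc1ccc(-c2nn(-c3ccc(Cl)cc3)cc2/C=N\c2ccccc2)cc1`: 72.6%
compound 3 `Cc1ccc(-c2nn(-c3ccc(Cl)cc3)cc2C(CC(=O)c2ccc(Cl)cc2)C(=O)c2ccc(F)cc2)cc1`: 19.4%

In a functional assay on the whole organism (strain Wistar albino) for inhibition, with Rattus norvegicus as the target, read by paw edema, with stated times of 1 h and 3 h, at a dose of 0.32 mmol/kg by the intraperitoneal route (a lower number here means less inhibition, a higher number more inhibition at the dose given (going by the name of the read-out)), compound 1 gives 49.3% and compound 2 gives 72.6%. The change between them is methoxy in place of methyl on an aromatic carbon and it made a step of a number 23.3 percentage points higher from compound 1 to compound 2 (beyond the scatter). Compound 3 has the lowest number of the three in this assay, at 19.4%. The difference between the core of compound 3 and the core of compound 1 is not broken down here.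

Compound 4 `COc1ccc(-c2nn(-c3ccc(Cl)cc3)cc2C(CC(=O)c2ccc(Cl)cc2)C(=O)c2ccc(F)cc2)cc1` is not yet measured. It differs from compound 3 by methoxy in place of methyl on an aromatic carbon, the same kind of change as from compound 1 to compound 2, at a place described in the same words. Because compound 1 to compound 2 gave a number 23.3 percentage points higher from compound 1 to compound 2 (beyond the scatter), a step of about the same size is expected here, with room for the different core: a number 18.6 percentage points higher from compound 3 to compound 4 (beyond the scatter). Compound 4 is estimated at 38%, within 20% to 58%.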

Compound 4, a percentage reported as inhibition, in the whole organism at one dose (the size of the read-out at that dose, not a potency): 37.8%
For compound 4 the middle estimate is 0.2 percentage points above the measured one; the range from low to high includes it.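

In this assay, replacing 4-methylphenyl with 4-methoxyphenyl gave a number 18.4 percentage points higher from compound 3 to compound 4 (beyond the scatter), and the change carries from one core to the other with no difference in step size that can be told apart: the same change on two cores in this assay, a number 23.3 percentage points higher (beyond the scatter) from compound 1 to compound 2 and a number 18.4 percentage points higher (beyond the scatter) from compound 3 to compound 4, 4.9 percentage points apart, within the scatter of two such steps. This shows the same direction and a comparable size on these two cores, at one dose and in one read-out. It does not show that the step holds on any other core, and it gives no reason for the effect or any measure of potency.

Still open, from the compounds shown here alone, is whether a longer chain such as ethoxy, or a hydroxyl or an amine, would behave like methoxy at this place. Also open, going by these compounds, is what a carboxylic acid there would do on either core.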